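A few compounds are considered here, and "the series" means these few. Any claim that something is new, unique, unknown or untested is made for them only; others in the source may bear on it.

This piece follows one change made to compound 3 `Nc1ncnc2c1ccn2COCCO`. In a functional assay on HFF cells (Homo sapiens) for cytotoxicity (a higher number here means a weaker inhibitor, a lower number a stronger inhibitor), compound 3 gives > 100000 nM, which is a limit of the assay and not a measured number. Compound 3 thus stands at the limit of > 100000 nM in this assay, at which 1 of the 3 values shown sits. For comparison, compound 1 `CSc1nc(Cl)c2ccn(COCCOC(C)=O)c2n1` gives 100000 nM in this assay, and compound 2 `CSc1nc(Cl)c2ccn(COCCO)c2n1` gives 30000 nM. Going by the values given here, the only step between two measured compounds is a 3.3-fold lower number from compound 1 to compound 2 (0.52 log units; beyond the scatter), a change on the side chain rather than on the ring. Compound 4 `COc1nc(N)c2ccn(COCCO)c2n1` is the compound still to be measured. It differs from compound 3 by methoxy in place of hydrogen on an aromatic carbon. Among the compounds with values here, no measured step touches this position of the ring, so the comparison of compound 1 with compound 2 offers little guidance beyond showing that a small change on the side chain moved the number only modestly. The step expected in this assay is a number no higher from compound 3 to compound 4 (the limit leaves the size open), which amounts to none beyond the scatter. Compound 4 is therefore estimated at 100000 nM, with a range from 40000 nM to 300000 nM.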

Compound 4, half-maximal inhibitory concentration: > 100000 nM
Compound 4: only a limit was reported; the forecaster's own chance of this, stated with the estimate: 55%; the middle value sits exactly at the limit.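

Compound 3 and compound 4 each give only a limit and not a measured number, so the step between them cannot be read. The compounds shown leave open whether methoxy in place of hydrogen on this aromatic carbon changes the number at all.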